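A few compounds are considered here, and "the series" means these few. Any claim that something is new, unique, unknown or untested is made for them only; others in the source may bear on it.

Measured compounds:
Compound 1, `O=C1CC(c2ccc(Cl)cc2)Nc2c(Br)cc(Br)cc21`, gives > 100000 nM in a functional assay on MCF7 cells (Homo sapiens) for cytotoxicity, read by sulforhodamine B assay, with a stated time of 48 h; on this read-out higher numbers stand for lower toxicity in this test and lower numbers for higher toxicity in this test. That value is a limit of the assay, not a number.
Compound 2, `O=C1CC(c2ccc(Br)cc2)Nc2c(Br)cc(Br)cc21`, gives > 100000 nM in this assay. That value is again a limit of the assay.
Compound 3, `COc1ccc(C2CC(=O)c3cc(Br)cc(Br)c3N2)cc1`, gives > 100000 nM in this assay. That value is also a limit of the assay.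

Compound 3 therefore stands at the limit of > 100000 nM in this assay, at which 3 of the 3 values shown sit, and the two other values sit at the same place. Within the data shown here, none of the measured steps can be read: a step that the two limits leave unreadable from compound 1 to compound 2, a step that the two limits leave unreadable from compound 1 to compound 3 and a step that the two limits leave unreadable from compound 2 to compound 3 all remain unreadable between the limits, with no size and no direction.

Compound 4, `O=C1CC(c2ccc(O)cc2)Nc2c(Br)cc(Br)cc21`, differs from compound 3 by hydrogen in place of methyl on an oxygen on an aromatic ring. Among the measured compounds shown here, no measured step touches an oxygen on the aromatic ring. The three measured steps exchange groups on an aromatic carbon, and they give no size for a change of that kind either. The expected step that the limit leaves unreadable from compound 3 to compound 4 in this assay thus rests on nothing more than the shared limit of the three measured compounds, and no direction beyond the scatter is expected from it. Compound 4 is therefore expected to give 150000 nM, with a range from 40000 nM to 600000 nM, and is most likely to be reported as a limit as well.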

Compound 4, concentration lethal to 50% of the cells: > 100000 nM
Compound 4: only a limit was reported (the forecaster's own chance of this, stated with the estimate: 80%); the middle value is on the limit's open side.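

No new step can be read from compound 4 to compound 1, compound 2 or compound 3 in this assay, since all four compounds give only a limit of the assay: the limit of > 100000 nM in this assay, at which 4 of the 4 values shown sit.
The compounds shown leave open how far each lies past that limit, and whether exchanging chloro, bromo, methoxy or hydroxy changes the value at all.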